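Thioamide in place of amide on a cyclopropyl carboxamide

This account rests on a few compounds, and the source may have more. Where it says the series, first, only, none or still open, it means among the compounds named here.

Measured compounds:
- Compound 1 `Nc1sc(-c2ccc(Cl)cc2)c(-c2ccc(Cl)cc2)c1C(=O)NC1CC1`: 3680 nM
- Compound 2 `Nc1sc(-c2ccc(Br)cc2)c(-c2ccc(Cl)cc2)c1C(=O)NC1CC1`: 37300 nM
- Compound 3 `Nc1sc(-c2ccc([N+](=O)[O-])cc2)c(-c2ccc(Cl)cc2)c1C(=O)NC1CC1`: "not determined" (no result reported)

Compound 1 was tested in a functional assay on PC-3 cells (Homo sapiens) for cytotoxicity, read by sulforhodamine B assay, with a stated time of 72 h (on this read-out higher numbers stand for weaker inhibition and lower numbers for stronger inhibition), where compound 1 gives 3680 nM. Going by the values given here, that is the lowest of the two numbers known here; the nearest neighbour, compound 2, gives 37300 nM, and the step of a 10-fold higher number from compound 1 to compound 2 (1.01 log units; beyond the scatter) is a large one. Compound 3 carries a nitro group in place of the bromo of compound 2, and for compound 3 the result stands as "not determined" (no result reported).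

Compound 4 `Nc1sc(-c2ccc(Cl)cc2)c(-c2ccc(Cl)cc2)c1C(=S)NC1CC1` differs from compound 1 in one place: a group of 6 heavy atoms (4 carbon, 1 nitrogen, 1 sulfur; one three-membered non-aromatic ring of carbon only) in place of a group of 6 heavy atoms (4 carbon, 1 nitrogen, 1 oxygen; one three-membered non-aromatic ring of carbon only), on an aromatic carbon. Among the compounds with values here, none of the measured steps touches this position; the single known step concerns a halogen on an aromatic carbon and says nothing about the carboxamide. With no guide, the estimate for compound 4 keeps it near compound 1, and the expected step of a 1.1-fold lower number from compound 1 to compound 4 (0.02 log units; within the scatter) in this assay is not beyond the scatter. For compound 4 the expected value is therefore 3500 nM, within a range of 1100 nM to 12000 nM.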

Compound 4, half-maximal inhibitory concentration: 22100 nM
Compound 4: the middle estimate sits 6.3-fold (0.80 log units) below what was measured, outside the stated range (above it).
By their numbers in this assay, from the lowest: compound 1; then compounds 4 and 2 (each within the scatter of the next).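

Exchanging the oxygen of the cyclopropylcarbamoyl group for sulfur, with the three-membered ring kept, gives a 6.0-fold higher number from compound 1 to compound 4 (0.78 log units; beyond the scatter) in this assay. Going by these compounds alone, the earlier compounds varied only a halogen on an aromatic carbon, so this is the first sign that the carboxamide position also responds to change, and that a replacement as close as this one does not leave the number where it was. Nothing measured here accounts for the shift.

Going by these compounds, it remains open whether sulfur in this place would have the same effect with the bromo group of compound 2 on the core. On these data alone, it is also open how a carboxylic acid, an ester or a longer chain on the amide nitrogen would compare with the cyclopropyl carboxamide of compound 1.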